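The source may hold more compounds than are shown below. What is called first, only, known or untested is meant among the compounds shown, and "the series" means these compounds.

Within a functional assay on isolated protein for inhibition of Glucose-dependent insulinotropic receptor (Rattus norvegicus), read by HTRF and cAMP accumulation (a lower number here means a smaller maximal response, a higher number a larger maximal response), three compounds of the series have numbers. Compound 1 `Cc1nc(S(C)(=O)=O)ccc1Oc1ncnc(OC2CCN(C(=O)O[C@H](C)C(F)(F)F)CC2)c1F` gives 85%. Compound 2 `Cc1nc(S(C)(=O)=O)ccc1Oc1ncnc(OC2CCN(C(=O)O[C@@H](C)C(F)(F)F)CC2)c1F` gives 80%; the step of a number 5 percentage points lower from compound 1 to compound 2 (within the scatter) rests on (the fact that compounds 1 and 2 differ only in the configuration as drawn). Compound 3 `Cc1nc(S(C)(=O)=O)ccc1Oc1ncnc(OC2CCN(C(=O)OC3COC3)CC2)c1F` gives 66%, the lowest of the three: the steps of a number 19 percentage points lower from compound 1 to compound 3 (beyond the scatter) and a number 14 percentage points lower from compound 2 to compound 3 (beyond the scatter) both exceed the scatter and both come from exchanging the group on the oxygen of the carbamate.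

Compound 4 `Cc1nc(S(C)(=O)=O)ccc1Oc1ncnc(OC2CCN(C(=O)C(F)(F)F)CC2)c1F` is not yet measured in this assay. It differs from compound 3 by trifluoromethyl in place of (oxetan-3-yl)oxy on a carbonyl carbon, so the ((oxetan-3-yl)oxy)carbonyl of compound 3 becomes a (trifluoromethyl)carbonyl. Within the data shown here, the steps that bear on this change are those into compound 3, which were modest and downward when oxetan-3-yl replaced 1-(trifluoromethyl)ethyl; the reverse direction, a fluorinated group entering in place of the oxetanyl group, is therefore expected to move the number modestly upward, toward the range of compound 1 and compound 2, though no measured step covers an amide in place of a carbamate. Compound 4 is therefore estimated at 76%, expected between 58% and 94%, a step of a number 10 percentage points higher from compound 3 to compound 4 (within the scatter).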

Compound 4, largest response reached (reported as efficacy), in percent of the reference or control that the assay uses: 76%
For compound 4 middle estimate and measured number coincide at the digits printed; the range from low to high includes it.
By their numbers in this assay, from the lowest: compounds 3, 4, 2 and 1 (each within the scatter of the next, the first and the last beyond it).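

On the carbonyl carbon whose other neighbour is the amide-type nitrogen in a ring, trifluoromethyl replaces the alkoxy groups of the carbamates without a step beyond the scatter in this assay: a number 10 percentage points higher from compound 3 to compound 4 (within the scatter), a number 4 percentage points lower from compound 2 to compound 4 (within the scatter) and a number 9 percentage points lower from compound 1 to compound 4 (within the scatter). Compound 4 therefore shows that a carbonyl group without the carbamate oxygen still gives a large maximal response, but it cannot be placed on either side of the gap that separates compound 3 from compounds 1 and 2. The data shown give no cause for these steps.

Open, from the compounds shown here alone, is whether a plain methyl group, a longer chain or a cyclic amine on this carbonyl carbon would keep the response. Also open, going by these compounds, is whether the fluorine atoms of the trifluoromethyl group contribute to the response of compound 4.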